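A few compounds are considered here, and "the series" means these few. Any claim that something is new, unique, unknown or untested is made for them only; others in the source may bear on it.

Measured compounds:
- compound 1, `CCCCNC(=O)OC/C=C(\C)C1=CC(=O)C(C)(C)O1`: 5.3 ug/mL
- compound 2, `C/C(=C\C=C/C1CCCCC1)C1=CC(=O)C(C)(C)O1`: 7.1 ug/mL
- compound 3, `C/C(=C\C=C\c1ccccc1)C1=CC(=O)C(C)(C)O1`: 14 ug/mL

All three were tested in a functional assay on MOLT-4F cells (Homo sapiens) for inhibition; on this read-out lower numbers stand for stronger inhibition and higher numbers for weaker inhibition. Compound 1 gives the lowest number of the three. Compound 2 lies within the scatter of compound 1, so the two cannot be told apart. Compound 3 returns a higher number than compound 1, and that gap lies beyond the scatter. Within the data shown here, no pair of measured compounds differs in only one place, so no single-change step is available among them.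

Compound 4, `C=CCNC(=O)OC/C=C(\C)C1=CC(=O)C(C)(C)O1`, has not yet been measured in this assay. It differs from compound 1 in one place: vinyl in place of propyl on a saturated chain carbon bound to an amide-type nitrogen. Cut one bond further out, the same change reads butyl to allyl. The rest of compound 1 is unchanged. Among the measured compounds shown here, with no measured step of this kind to lean on, the expected step is small: a 1.0-fold higher number from compound 1 to compound 4 (0.02 log units; within the scatter), a shift expected to stay within the scatter, with no direction favoured. Compound 4 is estimated at 5.5 ug/mL, with a range from 2.5 ug/mL to 12 ug/mL.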

Compound 4, half-maximal inhibitory concentration: 7.7 ug/mL
For compound 4 the middle estimate is 1.4-fold (0.15 log units) below the measured one; the range from low to high includes it.
By their numbers in this assay, from the lowest: compounds 1, 2, 4 and 3 (each within the scatter of the next, the first and the last beyond it).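

Butylamino to allylamino on the carbamate gives the series its first single-change step in this assay: a 1.5-fold higher number from compound 1 to compound 4 (0.16 log units; within the scatter) stays within the scatter, so at this place, on a saturated chain carbon bound to an amide-type nitrogen, vinyl in place of propyl leaves the read-out indistinguishable. Propyl and vinyl differ both in carbon count and in the double bond, and this one step cannot separate those two differences. No measured evidence bears on the reason for this result.

The compounds shown leave open whether this place stays as undemanding with a longer chain such as hexyl, with a benzyl group, or with a chain ending in an amine or a carboxylic acid. They also leave open whether a saturated propyl chain would read differently from the butyl of compound 1.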